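Iodo for Acetyl: What Compound 4 Might Show

The compounds below may be only part of what the source reports. "The series", "measured", "known", "first", "only" and "open" are said of these compounds alone.

The measured compounds and their values:
compound 1 `COC(=O)c1c[nH]c2cc(OCCOc3ccccc3)c(OC)cc2c1=O`: > 20000 nM
compound 2 `CCCCc1cc2c(=O)c(C(C)=O)c[nH]c2cc1OCCOc1ccccc1`: "not determined" (no result reported)
compound 3 `COC(=O)c1c[nH]c2cc(-c3ccccc3)ccc2c1=O`: > 20000 nM

These three compounds were tested in an ADME assay on J774 cells (Mus musculus) for cytotoxicity; on this read-out higher numbers stand for an effect only at larger amounts of compound and lower numbers for an effect already at smaller amounts. Compound 1 reaches only a limit of the assay, > 20000 nM, and not a number. Compound 3 likewise sits at a limit, > 20000 nM. The shared feature of the set is the limit of > 20000 nM in this assay, at which 2 of the 3 values shown sit. Compound 2 stands apart: in this assay compound 2 gives "not determined" (no result reported), so no single number is available for it.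

Compound 4 `CCCCc1cc2c(=O)c(I)c[nH]c2cc1OCCOc1ccccc1` differs from compound 2 in one place: iodo in place of acetyl on an aromatic carbon. Going by the values given here, no step between measured compounds is available, and compound 2 itself has no number, so no size of step in this assay can be given for this change; the two values that do exist are both limits.

On that footing, compound 4 is expected to behave like the measured compounds in this assay, with an estimated value of 20000 nM, between 5000 nM and 60000 nM, and a strong chance that only a limit is reported.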

Compound 4, half-maximal effective concentration: > 10000 nM
Compound 4: only a limit was reported; the forecaster's own chance of this, stated with the estimate: 60%; the middle value does not contradict the limit.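

In this assay compound 4 gives > 10000 nM, which is a limit of the assay and not a number. Going by these compounds alone, compound 2 gives "not determined" (no result reported), and no step between compound 2 and compound 4 can be read. The compounds shown leave open whether iodo in place of acetyl alters the cytotoxic effect at all.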